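Fluoro for chloro at two places across two cores

The source may report more compounds than this note shows. Statements on the series, on what has been measured and on what is new or still open speak of the compounds shown alone.

Compound 1 `COc1ccc(S(=O)(=O)c2cnc3cc(F)ccc3c2-c2cccc(F)c2)cc1Cl` and compound 2 `COc1ccc(S(=O)(=O)c2cnc3cc(F)ccc3c2-c2cccc(Cl)c2)cc1Cl` share one core; compound 3 `O=S(=O)(c1ccc(F)cc1)c1cnc2ccc(Cl)cc2c1-c1ccc(Cl)cc1` and compound 4 `O=S(=O)(c1ccc(F)cc1)c1cnc2ccc(F)cc2c1-c1ccc(Cl)cc1` share another, and the difference between the two cores is not broken down here. In an ADME assay on microsomes from liver (Homo sapiens) for metabolic stability, tested at 2.5 uM (on this read-out higher numbers stand for fast clearance and lower numbers for slow clearance), compound 1 gives 2.08 mL/min, and compound 2 gives 1.19 mL/min. In this assay compound 3 gives 0.01 mL/min, the lowest of the three measured numbers and beyond the scatter from both others.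

The change from compound 2 to compound 1 is fluoro in place of chloro on an aromatic carbon, and it made a 1.7-fold higher number from compound 2 to compound 1 (0.24 log units; within the scatter). Compound 4 carries the same kind of change against compound 3, (fluoro in place of chloro on an aromatic carbon); here the place is on an aromatic carbon of a six-membered aromatic ring of carbon only, part of a fused or bridged system of two rings, meta to a fused ring and para to a fused ring, whereas in the earlier pair it was meta to a large group. Within the data shown here, only one measured example of this change exists, so the expectation rests on that single step a 1.7-fold higher number from compound 2 to compound 1 (0.24 log units; within the scatter) and on compound 3 at 0.01 mL/min. The expected step is a 1.5-fold higher number from compound 3 to compound 4 (0.18 log units; within the scatter), a small one. Compound 4 is estimated at 0.015 mL/min in this assay, with a range from 0.005 mL/min to 0.05 mL/min.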

Compound 4, intrinsic clearance in a liver preparation (reported as CLH), per the amount of preparation that the assay uses: 0.12 mL/min
Estimate against measurement, compound 4: 8.0-fold (0.90 log units) below; the whole stated range lies below it.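

In this assay, fluoro in place of chloro on an aromatic carbon gave a 12-fold higher number from compound 3 to compound 4 (1.08 log units; beyond the scatter), and the size of this step did not carry over from one core to the other: the same change on two cores in this assay, a 1.7-fold higher number (0.24 log units; within the scatter) from compound 2 to compound 1 and a 12-fold higher number (1.08 log units; beyond the scatter) from compound 3 to compound 4, 6.9-fold (0.84 log units) apart, beyond the scatter of two such steps. Both steps point the same way, but only this one lies beyond the scatter, so a step read on one core is a poor guide to its size on the other in this series. The four compounds do not show what sets the gap, since the two pairs differ both in the core and in the place of the change, and two pairs cannot separate these.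

Still open, on these data alone, is how the same exchange reads on each core with the place held fixed, which would separate core from place. Also open, as far as these compounds go, is how a group other than the two halogens, such as a nitrile or an amine, would read at the place changed in compound 4.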